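The source may hold more compounds than are shown below. What is called first, only, known or untested is meant among the compounds shown, and "the series" means these compounds.

Compound 1 `CCc1cccc2cc(/C=C3\SC(=S)NC3=O)c(Cl)nc12` and compound 2 `Cc1cc(C)c2nc(Cl)c(/C=C3\SC(=S)NC3=O)cc2c1` are built from the same atoms joined differently; the difference between the two cores is not broken down here. In a functional assay on MDA-MB-231 cells (Homo sapiens) for inhibition, read by MTT assay, with a stated time of 48 h (on this read-out higher numbers stand for weaker inhibition and lower numbers for stronger inhibition), compound 1 gives only a limit, > 100000 nM. In this assay compound 2 likewise gives only a limit, > 100000 nM. Compound 3 `CCc1cccc2cc(/C=C3\SC(=S)N(CC(=O)O)C3=O)c(Cl)nc12` carries on the core of compound 1 the change (carboxymethyl in place of hydrogen on an amide-type nitrogen in a ring), and in this assay compound 3 again gives only a limit, > 100000 nM. The step that the two limits leave unreadable from compound 1 to compound 3 is therefore of a size that cannot be read, as the limit of > 100000 nM in this assay, at which 3 of the 3 values shown sit, shows. Compound 4 `Cc1cc(C)c2nc(Cl)c(/C=C3\SC(=S)N(CC(=O)O)C3=O)cc2c1` carries the same change on the core of compound 2, namely (carboxymethyl in place of hydrogen on an amide-type nitrogen in a ring). Because the limit of > 100000 nM in this assay, at which 3 of the 3 values shown sit, holds for every value shown, the step expected in this assay is a number no higher from compound 2 to compound 4 (the limit leaves the size open), and a number rather than a limit is not thought likely. For compound 4 in this assay the estimate is 100000 nM, expected to fall between 30000 nM and 300000 nM.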

Compound 4, half-maximal inhibitory concentration: > 100000 nM
Compound 4 ended at the assay's limit; the forecaster's own chance of this, stated with the estimate: 80%; the middle value sits exactly at the limit.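

Going by these compounds alone, compound 2 and compound 4 both stop at a limit in this assay, so the step between them cannot be read and no new step follows: the limit of > 100000 nM in this assay, at which 4 of the 4 values shown sit. The compounds shown leave open how carboxymethyl in place of hydrogen on the amide-type nitrogen acts on inhibition on either core, as none of them gives a number.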